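From 2-chlorophenyl to 3-chlorophenyl on the shared core

A few compounds are considered here, and "the series" means these few. Any claim that something is new, unique, unknown or untested is made for them only; others in the source may bear on it.

Of the compounds shown here, three built on one shared core have been measured in a functional assay on HepG2 cells (Homo sapiens) for inhibition, read by MTT assay, with a stated time of 72 h; on this read-out higher numbers stand for weaker inhibition and lower numbers for stronger inhibition. Compound 1 `C#CCSc1nc(NCCC(C)C)c2ccncc2n1` reaches only a limit, > 80000 nM. Compound 2 `C#CCSc1nc(NCCC#N)c2ccncc2n1` also reaches only a limit, > 80000 nM. Within the data shown here, compound 3 `C#CCSc1nc(Nc2ccccc2Cl)c2ccncc2n1` gives 17200 nM, the only true number among the three.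

Compound 4 `C#CCSc1nc(Nc2cccc(Cl)c2)c2ccncc2n1` carries 3-chlorophenyl in place of 2-chlorophenyl on a nitrogen on an aromatic ring. Among the measured compounds shown here, no measured step makes this exact change, so the evidence is indirect. Putting 2-chlorophenyl in place of isopentyl gave an at least 4.6-fold lower number from compound 1 to compound 3 (0.66 log units; beyond the scatter), and putting it in place of 2-cyanoethyl gave an at least 4.6-fold lower number from compound 2 to compound 3 (0.66 log units; beyond the scatter). Both steps replace the whole group on that nitrogen, whereas compound 4 keeps a chlorophenyl group there. A step beyond the scatter is therefore not expected in this assay, and no direction is favoured. The expected result is a 1.2-fold higher number from compound 3 to compound 4 (0.07 log units; within the scatter). The estimated value for compound 4 is 20000 nM. Its expected range runs from 8000 nM to 50000 nM.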

Compound 4, half-maximal inhibitory concentration: 1090 nM
For compound 4 the middle estimate is 18-fold (1.26 log units) above the measured one; measured number below the stated range.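

In this assay, the identity of the group on the nitrogen is not the whole story: the two chlorophenyl groups have the same atoms joined differently, yet 3-chlorophenyl in place of 2-chlorophenyl gives a 16-fold lower number from compound 3 to compound 4 (1.20 log units; beyond the scatter). The earlier compounds shown here showed only what happens when the whole group on this nitrogen is replaced, and this step shows that the place of the chlorine on the phenyl ring matters as well. The steps of an at least 73-fold lower number from compound 2 to compound 4 (1.86 log units; beyond the scatter) and an at least 73-fold lower number from compound 1 to compound 4 (1.86 log units; beyond the scatter) give only a minimum size, as each starts from a limit of the assay: the limit of > 80000 nM in this assay, at which 2 of the 4 values shown sit.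

The compounds shown leave open why the place of the chlorine matters so much. They also leave open how a plain phenyl group or a bromophenyl group on this nitrogen would compare.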